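This account rests on a few compounds, and the source may have more. Where it says the series, first, only, none or still open, it means among the compounds named here.

Working notes on the series. Compound 1 `COc1nc(-c2cc3ccccc3o2)cc(-c2ccc(Cl)cc2Cl)c1C#N` gives 322000 nM in a functional assay on aorta (strain Wistar) for inhibition, with Thoracic aorta (Rattus norvegicus) as the target; on this read-out lower numbers stand for stronger inhibition and higher numbers for weaker inhibition. Compound 2 `CCOc1nc(-c2cc3ccccc3o2)cc(-c2ccc(Cl)cc2Cl)c1C#N` gives 442000 nM in this assay; the step is a 1.4-fold higher number from compound 1 to compound 2 (0.14 log units; within the scatter), a change described as methyl in place of hydrogen on a saturated chain carbon bound to an oxygen on an aromatic ring. Compound 3 `CCn1cc(-c2cc(-c3cc4ccccc4o3)nc(OC)c2C#N)c2ccccc21` gives 299000 nM in this assay. The difference between the core of compound 1 and the core of compound 3 is not broken down here. Compound 4 `CCOc1nc(-c2cc3ccccc3o2)cc(-c2cn(CC)c3ccccc23)c1C#N` is not yet measured; it differs from compound 3 by methyl in place of hydrogen on a saturated chain carbon bound to an oxygen on an aromatic ring, the same change as that from compound 1 to compound 2, at a place described in identical words. Because the earlier step was a 1.4-fold higher number from compound 1 to compound 2 (0.14 log units; within the scatter), a step of similar size, within the scatter, is expected here, namely a 1.4-fold higher number from compound 3 to compound 4 (0.15 log units; within the scatter). Compound 4 is therefore estimated at 420000 nM in this assay, with a range from 200000 nM to 900000 nM.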

Compound 4, half-maximal inhibitory concentration: 358000 nM
The estimate for compound 4 lay 1.2-fold (0.07 log units) above the measured number, within the range that was stated.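

Methoxy to ethoxy gives a 1.2-fold higher number from compound 3 to compound 4 (0.08 log units; within the scatter) in this assay on the core of compound 3. Within this pair of cores, the size of the step shows no difference that can be resolved: the same change on two cores in this assay, a 1.4-fold higher number (0.14 log units; within the scatter) from compound 1 to compound 2 and a 1.2-fold higher number (0.08 log units; within the scatter) from compound 3 to compound 4, 1.1-fold (0.06 log units) apart, within the scatter of two such steps. Among these compounds, this shows only that the change behaves alike on these two cores; since neither step lies beyond the scatter, it does not show that a real effect of the change carries from one core to the other.

Propoxy, a longer chain, or an amine at this place does not appear among the compounds shown. From the compounds shown here alone, it remains open whether any such group would move the number beyond the scatter, and whether the agreement would hold on a third core.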